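The compounds below may be only part of what the source reports. "The series", "measured", "known", "first", "only" and "open" are said of these compounds alone.

In an in vivo ADME assay on the whole organism for pharmacokinetics, with Canis familiaris (Canis lupus familiaris) as the target, at a dose of 0.6 mg/kg (a lower number here means slower removal, a higher number faster removal of the compound), compound 1 (`CC[C@H](C)[C@@H]1C(=O)N[C@H](C2Cc3ccccc3C2)C(=O)N1[C@@H](C(=O)N(C)C)c1ccc(C)[n+]([O-])c1`) gives 14 mL/min/kg and compound 2 (`CC[C@@H](C)[C@@H]1C(=O)N[C@H](C2Cc3ccccc3C2)C(=O)N1[C@@H](C(=O)N1CCOCC1)c1ccc(C)nc1`) gives 20 mL/min/kg so compound 2 stands within the scatter of compound 1. Compound 3 (`CC[C@H](C)[C@@H]1C(=O)N[C@H](C2Cc3ccccc3C2)C(=O)N1[C@@H](C(=O)N1CCOCC1)c1ccc(C)nc1`) comes from compound 2 through the two compounds have the same atoms and bonds and differ only in configuration as drawn: 1 of 4 stereo elements differ; a stereocentre at a saturated chain carbon is drawn R in compound 2 and S in compound 3 and a stereocentre at a saturated chain carbon is drawn R in compound 2 and S in compound 3. Among the measured compounds shown here, no measured step between compounds differing in one place is available to size this change. No shift beyond the scatter is expected in this assay in either direction. The expected change is a 1.1-fold lower number from compound 2 to compound 3 (0.05 log units; within the scatter) and stays within the scatter. Compound 3 is expected at 18 mL/min/kg within an estimated range from 8 mL/min/kg to 38 mL/min/kg in this series.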

Compound 3, clearance: 23 mL/min/kg
For compound 3 the middle estimate is 1.3-fold (0.11 log units) below the measured one, and the stated range covers the measured number.
By their numbers in this assay, from the lowest: compounds 1, 2 and 3 (each within the scatter of the next).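

In this assay, turning a stereocentre at a saturated chain carbon from R to S gives a 1.2-fold higher number from compound 2 to compound 3 (0.06 log units; within the scatter). No earlier step sized any change at this position; this one shows that the configuration at this carbon, in this series, leaves the clearance within the scatter. The comparison speaks for that carbon alone, for one reason: the fact that compounds 2 and 3 differ only in the configuration as drawn

On these data alone, whether the other stereocentres behave in the same way remains open. Also open, as far as these compounds go, is whether a longer chain or a cyclopropyl group in place of this saturated chain would shift clearance beyond the scatter.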